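This account rests on a few compounds, and the source may have more. Where it says the series, first, only, none or still open, it means among the compounds named here.

Measured compounds:
compound 1 `Cc1ccc(-c2ccc(Cl)c(C(=O)NCC3(O)CCCCCC3)c2)nn1` — in a functional assay on HEK293 cells for antagonist activity at P2X purinoceptor 7 (Homo sapiens) (a lower number here means a stronger inhibitor, a higher number a weaker inhibitor), compound 1 gives 18 nM
compound 2 `O=C(NCC1(O)CCCCCC1F)c1cc(-c2ncc(F)cn2)ccc1Cl` — in this assay compound 2 gives 17 nM

Compound 1 holds the higher of the two numbers recorded so far in this assay, but its value and that of compound 2 lie within the usual scatter of each other, so the two cannot be placed in order on this evidence. The two compounds also differ in more than one place, so nothing can be read from their pair about any single change.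

The compound still to be measured is compound 3 `Cc1cnc(-c2ccc(Cl)c(C(=O)NCC3(O)CCCCCC3)c2)cn1`. It differs from compound 1 only in one group: 5-methylpyrazin-2-yl in place of 6-methylpyridazin-3-yl on an aromatic carbon. Going by the values given here, the change keeps the same atoms and joins them differently, and no measured pair in this set isolates such a swap, so no step size is known for it. Given that compound 1 gives 18 nM in this assay, the expectation is a step of a 1.4-fold higher number from compound 1 to compound 3 (0.14 log units; within the scatter) from compound 1 to compound 3, that is, nothing beyond the scatter in either direction. Compound 3 is accordingly estimated at 25 nM in this assay, with a range from 8 nM to 80 nM.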

Compound 3, half-maximal inhibitory concentration: 22 nM
Compound 3: middle estimate off by 1.1-fold (0.06 log units), on the high side; measured number inside the range.
By their numbers in this assay, from the lowest: compounds 2, 1 and 3 (each within the scatter of the next).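

Going by these compounds alone, this pair is the first in the set to isolate a single change. In this assay, putting 5-methylpyrazin-2-yl in place of 6-methylpyridazin-3-yl on the aromatic carbon para to the chloro group gives a 1.2-fold higher number from compound 1 to compound 3 (0.09 log units; within the scatter) and so does not separate the two compounds. On this evidence, the position accepts this rearrangement of the same atoms, with the ring size and the counted hydrogen-bond acceptors unchanged, without a change that can be told from scatter, and no available measurement bears on why the two rings behave alike.

The compounds shown leave open whether the same holds for rings with a different nitrogen count or arrangement, such as pyridin-2-yl or 5-methylpyrimidin-2-yl, or for a methoxy, trifluoromethyl or longer alkyl chain in place of the methyl on the ring. They also leave open whether the swap between these two rings would stay as small on another amide side chain, such as the fluorine-bearing one of compound 2.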